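This account rests on a few compounds, and the source may have more. Where it says the series, first, only, none or still open, it means among the compounds named here.

In a functional assay on NCI-H460 cells (Homo sapiens) for cytotoxicity, read by MTT assay, with a stated time of 72 h (a lower number here means a stronger inhibitor, a higher number a weaker inhibitor), compound 1 (`Cc1ccc(S(=O)(=O)n2cc(COC3=C/C(=N\c4ccccc4)c4ccccc4C3=O)nn2)cc1`), which carries an unsubstituted phenyl group on the imine nitrogen, gives 7220 nM. Compound 2 (`Cc1ccc(S(=O)(=O)n2cc(COC3=C/C(=N\c4ccc(I)cc4)c4ccccc4C3=O)nn2)cc1`) gives > 16300 nM, and this is a limit of the assay and not a number. Compound 2 therefore has a limit rather than a measured position on the scale.

Compound 3 (`Cc1ccc(S(=O)(=O)n2cc(COC3=C/C(=N\c4ccc(Br)cc4)c4ccccc4C3=O)nn2)cc1`) differs from compound 2 at one place, with bromo in place of iodo on an aromatic carbon, para to a large group: bromo in place of iodo on an aromatic carbon. For the measured compounds named here, only one measured step bears on this change, and it concerns the same position: an at least 2.2-fold higher number from compound 1 to compound 2 (0.35 log units; beyond the scatter). That step took the number upward, beyond the scatter, when iodo replaced hydrogen. Compound 3 keeps a halogen at that position, so it is expected to remain a weak inhibitor, somewhere near or between the results for compound 1 and compound 2. The expected change is modest and toward a lower number, estimated as an at least 1.2-fold lower number from compound 2 to compound 3 (0.09 log units; that floor lies within the scatter). With a single step as a guide, this expectation is loose. For compound 3 the estimated value is 13000 nM, with an expected range of 6000 nM to 28000 nM.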

Compound 3, half-maximal inhibitory concentration: 9410 nM
The estimate for compound 3 lay 1.4-fold (0.14 log units) above the measured number; low and high end bracket the measured number.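

In this assay, going from 4-iodophenyl to 4-bromophenyl gives an at least 1.7-fold lower number from compound 2 to compound 3 (0.23 log units; that floor lies within the scatter). Compound 2 holds a limit and not a number, so this step can be read only as a floor, and its true size stays unknown: the limit of > 16300 nM in this assay, at which 1 of the 3 values shown sits.

The clearer new information comes from comparing bromo with hydrogen at the same place, which gives a 1.3-fold higher number from compound 1 to compound 3 (0.12 log units; within the scatter). Compound 1 and compound 3 therefore cannot be told apart in this assay, and the rise beyond the scatter seen when iodo replaced hydrogen does not appear with bromo.

The compounds shown do not tell whether any group at this place can bring the number beyond the scatter below that of compound 1, since neither halogen does so. They also leave open how a smaller halogen such as fluoro, or a group of another kind such as an amine or a carboxylic acid, would compare with hydrogen and bromo on the same phenyl ring.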